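The source may hold more compounds than are shown below. What is called first, only, known or untested is meant among the compounds shown, and "the series" means these compounds.

Of the compounds shown here, three have been measured in a functional assay on A-375 cells (Homo sapiens) for inhibition, read by MTT assay, with a stated time of 120 h; on this read-out lower numbers stand for stronger inhibition and higher numbers for weaker inhibition: compound 1 `CC(NC(=O)c1cccc(-c2ccc(NC(=O)Nc3ccc(Cl)c(C(F)(F)F)c3)cc2)c1)c1ccccc1` with 5170 nM, compound 2 `CNC(=O)/C=C/c1ccc(NC(=O)Nc2ccc(Cl)c(C(F)(F)F)c2)cc1` with 20900 nM, and compound 3 `CNC(=O)/C(C)=C/c1ccc(NC(=O)Nc2ccc(Cl)c(C(F)(F)F)c2)cc1` with > 50000 nM.

Compound 3 stands at the weak end: its value is only a limit of this assay, not a number, namely (the limit of > 50000 nM in this assay, at which 1 of the 3 values shown sits). Among the measured compounds shown here, the one measured step leading to it is an at least 2.3-fold higher number from compound 2 to compound 3 (0.37 log units; beyond the scatter), a shift toward weaker inhibition. Compound 4 `CNC(=O)c1cccc(-c2ccc(NC(=O)Nc3ccc(Cl)c(C(F)(F)F)c3)cc2)c1` differs from compound 3 by 3-(methylcarbamoyl)phenyl in place of 2-(methylcarbamoyl)prop-1-en-1-yl on an aromatic carbon. For the measured compounds named here, no measured step covers this change; compound 1 also carries an aromatic ring in that place and gives 5170 nM, a clear number. Compound 4 is therefore expected to move back to a measurable value, an at least 4.1-fold lower number from compound 3 to compound 4 (0.61 log units; beyond the scatter), with an estimated 12000 nM between 3000 nM and 45000 nM.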

Compound 4, half-maximal inhibitory concentration: 46500 nM
Compound 4: middle estimate off by 3.9-fold (0.59 log units), on the low side, outside the stated range (above it).
By their numbers in this assay, from the lowest: compound 1; then compound 2; then compound 4. At a limit, above all of these: compound 3.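

In this assay 3-(methylcarbamoyl)phenyl in place of 2-(methylcarbamoyl)ethenyl gives weaker inhibition (a 2.2-fold higher number from compound 2 to compound 4 (0.35 log units; beyond the scatter)). With this aromatic ring in place, the group on the amide nitrogen matters, since methyl in place of 1-phenylethyl gives a 9.0-fold higher number from compound 1 to compound 4 (0.95 log units; beyond the scatter). The value of compound 3 is a limit and not a number, so its step can be given only as a floor (an at least 1.0-fold lower number from compound 3 to compound 4 (0.03 log units; that floor lies within the scatter)), and that floor cannot be read as a change: the limit of > 50000 nM in this assay, at which 1 of the 4 values shown sits.

On these data alone, it remains open whether the stronger inhibition of compound 1 needs the phenyl ring of its 1-phenylethyl group. An ethyl or benzyl group on that amide nitrogen would help to separate these possibilities.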